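The compounds below may be only part of what the source reports. "The series", "measured", "known", "first", "only" and "open" are said of these compounds alone.

Among the compounds with values here, compound 3 `COc1cc(OC)c(-c2coc3cc(OCc4ccccc4C)ccc3c2=O)cc1OC` is the only member of the series with a number in a functional assay on HUVEC cells (Homo sapiens) for antiproliferative activity, read by MTT assay, with a stated time of 24 h; on this read-out lower numbers stand for stronger inhibition and higher numbers for weaker inhibition: compound 3 gives 4830 nM. Compound 1 `COc1cccc(C(=O)Oc2ccc3c(=O)c(-c4cc(OC)c(OC)cc4OC)coc3c2)c1` reaches only a limit, > 10000 nM. Compound 2 `COc1cc(OC)c(-c2coc3cc(OCc4ccc(F)cc4)ccc3c2=O)cc1OC` likewise sits at a limit, > 10000 nM. Both of these stand at the limit of > 10000 nM in this assay, at which 2 of the 3 values shown sit. The readable steps are an at least 2.0-fold lower number from compound 1 to compound 3 (0.31 log units; beyond the scatter) and an at least 2.0-fold lower number from compound 2 to compound 3 (0.31 log units; beyond the scatter); the step that the two limits leave unreadable from compound 1 to compound 2 cannot be sized. Compound 4 `COc1cc(OC)c(-c2coc3cc(OCc4ccccc4Cl)ccc3c2=O)cc1OC` differs from compound 3 by chloro in place of methyl on an aromatic carbon. Within the data shown here, none of the measured steps compares chloro with methyl on the benzyl ring, so no basis exists for a shift beyond the scatter, and the expected step is a 1.1-fold lower number from compound 3 to compound 4 (0.03 log units; within the scatter). Compound 4 is therefore estimated at 4500 nM, within 1500 nM to 12000 nM in this assay.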

Compound 4, half-maximal inhibitory concentration: > 10000 nM
Compound 4 ended at the assay's limit; the forecaster's own chance of this, stated with the estimate: 25%; at least 2.2-fold (0.34 log units) between middle value and limit.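

In this assay, chloro in place of methyl on an aromatic carbon, ortho to a large group, gives an at least 2.0-fold higher number from compound 3 to compound 4 (0.31 log units; beyond the scatter). Within the data shown here, this is the first step at this one place, and it shows that exchanging one heavy atom for another here is enough to lose the measurable value of compound 3. The steps among compound 1, compound 2 and compound 4 cannot be read, and compound 3 remains the only one not at the limit: the limit of > 10000 nM in this assay, at which 3 of the 4 values shown sit.

On these data alone, how far compound 1, compound 2 and compound 4 lie past that limit stays open. Also open, as far as these compounds go, is whether an ethyl group or an amine at this place would keep a measurable value.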